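The source may report more compounds than this note shows. Statements on the series, on what has been measured and on what is new or still open speak of the compounds shown alone.

Measured compounds:
compound 1 `COc1ccc2cc(CCC(C)(C)O)ccc2c1` gives 3%
compound 2 `COc1ccc2cc(CCC(C)OC(C)=O)ccc2c1` gives 38%
compound 3 `COc1ccc2cc(CCC(C)OC(=O)CC(C)(C)CC(=O)O)ccc2c1` has not yet been measured

Among the measured compounds shown here, in a functional assay on the whole organism (strain Wistar) for inhibition, with Rattus norvegicus as the target, with a stated time of 5 days, at a dose of 50 mg/kg by the oral route (on this read-out lower numbers stand for less inhibition and higher numbers for more inhibition at the one dose given (going by the name of the read-out)), compound 2 stands highest of the two numbers so far, with compound 1 the nearest and markedly lower. For the measured compounds named here, the single step that has been measured, a number 35 percentage points higher from compound 1 to compound 2 (beyond the scatter), involves the same position of the chain as the change now considered and shows that exchanging a free tertiary alcohol for an ester there brings a large rise. Compound 3 carries the change (1-(carboxymethyl)-1-methylethyl in place of hydrogen on a saturated chain carbon bound to a carbonyl carbon). This extends the ester's small methyl into a chain that ends in a carboxylic acid, leaving the ester link itself in place. Going by the values given here, no measured step touches this part of the molecule, so the step from compound 1 to compound 2 bears on it only indirectly: it says the number is higher with the ester in place, not how its far end may be changed. The step of a number 8 percentage points lower from compound 2 to compound 3 (within the scatter) is therefore expected to be modest, with a slight downward lean. Compound 3 is estimated to give 30% in this assay, within a range from 5% to 60%.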

Compound 3, a percentage reported as inhibition, in the whole organism at one dose (the size of the read-out at that dose, not a potency): 26%
Beside the measured number, compound 3's estimate is 4 percentage points above it; the measured number falls inside the stated range.
By their numbers in this assay, from the lowest: compound 1; then compound 3; then compound 2.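

Compound 2's ester can be extended at its far end without losing the whole effect in this assay: placing 1-(carboxymethyl)-1-methylethyl on the saturated chain carbon bound to a carbonyl carbon gives a number 12 percentage points lower from compound 2 to compound 3 (beyond the scatter). Among the compounds shown here, this is the first sign that the part of the ester beyond its carbonyl affects the read-out, since the step lies beyond the usual scatter, yet it is only a modest step for an entering group of 7 heavy atoms that ends in a carboxylic acid. No measurement available here explains why the number falls with this change.

The compounds shown leave open whether the drop belongs to the carboxylic acid at the chain end or to the added chain itself, a question that a compound with a plain alkyl chain of similar length, or with a methyl ester or an amine at that end, could help to separate. They also leave open how the number would respond to an amide in place of the ester link, with the rest of compound 2 kept the same.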